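A few compounds are considered here, and "the series" means these few. Any claim that something is new, unique, unknown or untested is made for them only; others in the source may bear on it.

Measured compounds in a functional assay on the whole organism (strain Wistar) for inhibition, with Rattus norvegicus as the target, read by paw edema, with stated times of 60 min and 24 h, at a dose of 100 mg/kg by the oral route; a lower number here means less inhibition, a higher number more inhibition at the dose given (going by the name of the read-out):

compound 1 `COc1cc2c(cc1OC)C(CC(N)=O)CC2`: 26.7%
compound 2 `CNC(=O)CC1CCc2cc(OC)c(OC)cc21`: 33.3%
compound 3 `COc1cc2c(cc1OC)C(CC(=O)NC(C)(C)C)CC2`: 40%

All three share one core and differ only at the amide nitrogen. Compound 3 holds the highest of the three numbers in this assay ; its gap to compound 2 lies within the scatter, its gap to compound 1 beyond it. The measured steps are a number 6.6 percentage points higher from compound 1 to compound 2 (within the scatter), a number 13.3 percentage points higher from compound 1 to compound 3 (beyond the scatter) and a number 6.7 percentage points higher from compound 2 to compound 3 (within the scatter).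

Compound 4 `COc1cc2c(cc1OC)C(CC(=O)N1CCCC1)CC2` carries the change (pyrrolidin-1-yl in place of (tert-butyl)amino on a carbonyl carbon). Among the compounds with values here, this removes the hydrogen-bond donor of the amide, which no measured step does; the three steps only vary the alkyl group on that nitrogen, and only the largest of them, from hydrogen to tert-butyl, exceeds the scatter. Hence no firm direction can be drawn for compound 4, and the expected step in this assay is a number 2 percentage points lower from compound 3 to compound 4 (within the scatter), not beyond the scatter. Compound 4 is estimated at 38%, with a range from 22% to 52%.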

Compound 4, a percentage reported as inhibition, in the whole organism at one dose (the size of the read-out at that dose, not a potency): 33.3%
The estimate for compound 4 lay 4.7 percentage points above the measured number; low and high end bracket the measured number.
By their numbers in this assay, from the lowest: compounds 1, 2, 4 and 3 (each within the scatter of the next, the first and the last beyond it).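

In this assay the swap of (tert-butyl)amino for pyrrolidin-1-yl on a carbonyl carbon, which takes away the hydrogen-bond donor, gives a number 6.7 percentage points lower from compound 3 to compound 4 (within the scatter) and so shows that a change of this kind at this position need not move the read-out beyond the scatter. Within the data shown here, the comparisons with the smaller amides read alike, with no change at the digits printed from compound 2 to compound 4 (within the scatter) and a number 6.6 percentage points higher from compound 1 to compound 4 (within the scatter), so compound 4, unlike compound 3, has no step from compound 1 that exceeds the scatter. Nothing at hand explains these numbers.

On these data alone, whether a carboxylic acid or a morpholin-4-yl group on the same carbonyl carbon would give a step beyond the scatter stays open. So does the effect of a longer chain between the shared core and the carbonyl.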